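A Second Chloro on the Benzylidene Ring of Compound 2

The source may report more compounds than this note shows. Statements on the series, on what has been measured and on what is new or still open speak of the compounds shown alone.

In a functional assay on SW1573 cells (Homo sapiens) for inhibition, read by sulforhodamine B assay, with a stated time of 48 h (a higher number here means a weaker inhibitor of growth, a lower number a stronger inhibitor of growth), compound 1 `CC(=O)OC/C(=C\c1ccc(Cl)cc1Cl)C(=O)c1ccc(Cl)cc1` gives 3400 nM. Compound 2 `CC(=O)OC/C(=C/c1ccc(Cl)cc1)C(=O)c1ccc(Cl)cc1` gives 5300 nM in this assay, the higher of the two numbers recorded, though its gap to compound 1 lies within the scatter. Compound 3 `CC(=O)OC/C(=C/c1ccc(Cl)cc1Cl)C(=O)c1ccc(Cl)cc1` has not yet been measured. It differs from compound 2 by chloro in place of hydrogen on an aromatic carbon. Among the compounds with values here, no measured step of this kind exists here, so no shift beyond the scatter is expected in either direction in this assay. Compound 3 is accordingly estimated at 4000 nM, within 1500 nM to 10000 nM. The expected step from compound 2 to compound 3 is a 1.3-fold lower number from compound 2 to compound 3 (0.12 log units; within the scatter).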

Compound 3, concentration for 50% growth inhibition: 21000 nM
The estimate for compound 3 lay 5.3-fold (0.72 log units) below the measured number; measured number outside the range, above it.
By their numbers in this assay, from the lowest: compounds 1 and 2 (each within the scatter of the next); then compound 3.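

In this assay, the change from 4-chlorophenyl to 2,4-dichlorophenyl is not neutral when the double bond is drawn Z: it gives a 4.0-fold higher number from compound 2 to compound 3 (0.60 log units; beyond the scatter). The configuration of the double bond also counts, with a 6.2-fold higher number from compound 1 to compound 3 (0.79 log units; beyond the scatter), and this gap reflects configuration alone: the fact that compounds 1 and 3 differ only in the configuration as drawn

The compounds shown leave open whether an amine or a methoxy group at this position would act as chloro does. They also leave open whether the same chloro step would hold with the double bond drawn E.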